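This account rests on a few compounds, and the source may have more. Where it says the series, first, only, none or still open, it means among the compounds named here.

Series notes. Compound 1 `CO[C@H]1CC[C@H](n2nc(Oc3cc(C(F)(F)F)ccn3)c3c(N)ncnc32)CC1` and compound 2 `Nc1ncnc2c1c(Oc1cc(C(F)(F)F)ccn1)nn2[C@@H]1CC[C@H](N)C1` share one core and differ only in the group carried on an aromatic nitrogen. In an ADME assay on microsomes from liver (Homo sapiens) for metabolic stability, read by LC-MS, using NADPH, with a stated time of 10 min, tested at 10 uM (on this read-out lower numbers stand for a shorter-lived compound and higher numbers for a longer-lived compound), compound 1 gives > 2.41 h, which is a limit of the assay and not a number. In this assay compound 2 likewise gives > 2.41 h, again a limit. The step that the two limits leave unreadable from compound 1 to compound 2 therefore cannot be read, since both values sit at the limit of > 2.41 h in this assay, at which 2 of the 2 values shown sit. Compound 2 thus stands at the limit of this assay, with no number of its own.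

Compound 3 `Nc1ncnc2c1c(Oc1cc(C(F)(F)F)ccn1)nn2C1CCC(O)C1` differs from compound 2 by 3-hydroxycyclopentyl in place of 3-aminocyclopentyl on an aromatic nitrogen. Among the compounds with values here, no measured step bears directly on this exchange: the one step is unreadable between two limits, and no measured compound carries a 3-hydroxycyclopentyl. With both measured neighbours at the limit, no step beyond the scatter is expected, and the estimated step is a step that the limit leaves unreadable from compound 2 to compound 3. Compound 3 is therefore expected at about 2.5 h, within 1.2 h to 5 h, with a real chance that this assay again reports only a limit.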

Compound 3, half-life: > 2.41 h
Compound 3: a limit, no number (the forecaster's own chance of this, stated with the estimate: 70%); the middle value is on the limit's open side.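

No new step can be read among compound 1, compound 2 and compound 3 in this assay, since all three values are limits of the assay and not numbers: the limit of > 2.41 h in this assay, at which 3 of the 3 values shown sit.

The compounds shown leave open whether 4-methoxycyclohexyl, 3-aminocyclopentyl and 3-hydroxycyclopentyl on an aromatic nitrogen differ at all in half-life.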